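The source may hold more compounds than are shown below. What is called first, only, known or untested is meant among the compounds shown, and "the series" means these compounds.

Measured so far in a functional assay on PANC-1 cells (Homo sapiens) for inhibition, read by MTT assay, with a stated time of 24 h, tested at 10 uM; a higher number here means more inhibition at the concentration tested (going by the name of the read-out), a lower number less inhibition:
compound 1 `CC(C)=CCC1Cc2c(OCCCNC(=O)c3cccs3)cc(=O)n(CCCO)c2CC1(C)C` gives 5.6%
compound 2 `CC(C)=CCC1Cc2c(OCCCOc3ccc(Cl)cc3)cc(=O)n(CCCO)c2CC1(C)C` gives 0%
compound 3 `COc1cccc(NC(=O)Oc2cc(=O)n(CCCO)c3c2CC(CC=C(C)C)C(C)(C)C3)c1` gives 0%

Compound 3 sits level with compound 2 at the digits given, the two together being the lowest of the three numbers; its nearest neighbour is compound 2 and its furthest is compound 1, and both gaps lie within the scatter, as does the step of a number 5.6 percentage points lower from compound 1 to compound 2 (within the scatter). Within the data shown here, none of the three separates from the others beyond the scatter, so no compound's number in this assay can be called higher or lower than another's here.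

Compound 4 `CC(C)=CCC1Cc2c(OC(=O)Nc3cccc(C(F)(F)F)c3)cc(=O)n(CCCO)c2CC1(C)C` differs from compound 3 in one place: trifluoromethyl in place of methoxy on an aromatic carbon. Among the measured compounds shown here, no measured step touches a substituent on that six-membered ring. The three steps recorded all exchange the group on the oxygen of the shared core, and each stayed within the scatter: a number 5.6 percentage points lower from compound 1 to compound 3 (within the scatter), no change at the digits printed from compound 2 to compound 3 (within the scatter), a number 5.6 percentage points lower from compound 1 to compound 2 (within the scatter). They bear on the question only in showing that three quite different groups at that end of the molecule all leave this assay near the floor. The exchange of a single aromatic substituent gives no basis for expecting anything else, so the step of a number 3 percentage points higher from compound 3 to compound 4 (within the scatter) is expected to lie within the scatter. Compound 4 is estimated at 3%, with a range from 0% to 15%.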

Compound 4, a percentage reported as inhibition, at one concentration (the size of the read-out at that concentration, not a potency): 0%
For compound 4 the middle estimate is 3 percentage points above the measured one, within the range that was stated.
By their numbers in this assay, from the lowest: compounds 2, 3, 4 and 1 (each within the scatter of the next).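

In this assay, among these compounds, the change from 3-methoxyphenyl to 3-(trifluoromethyl)phenyl gives no change at the digits printed from compound 3 to compound 4 (within the scatter), the first reading of a substituent on this six-membered aromatic ring rather than of the group on the oxygen of the shared core. Methoxy, with its hydrogen-bond acceptor, and trifluoromethyl, with none, therefore give the same printed number at this aromatic carbon, but compound 3 gives 0% and compound 4 gives 0%, so the pair shows only that neither group produces a measurable reading here, and a substituent that weakened the effect could not be told apart at this end of the scale. No measurement is at hand that would explain this result.

Open, from the compounds shown here alone, is whether an amine or a carboxylic acid on this same aromatic carbon would give a number clear of the scatter in this assay. Also open, going by these compounds, is whether a longer chain in place of the 3-hydroxypropyl group shared by all four compounds would give a reading against which this substituent could be compared at all.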